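Compound 4 against the nitrooxy chain of compound 1

A few compounds are considered here, and "the series" means these few. Any claim that something is new, unique, unknown or untested is made for them only; others in the source may bear on it.

In a functional assay on thoracic aorta (strain Wistar) for inhibition, with Aorta (Rattus norvegicus) as the target, with a stated time of 120 min, in the presence of a further agent that is not named here (a higher number here means that more compound is needed for the effect, a lower number that less compound is needed), compound 1 (`CCCCNC(=O)NS(=O)(=O)c1ccc(OCCCO[N+](=O)[O-])cc1`) gives > 100000 nM, which is a limit of the assay and not a number. Any step starting from compound 1 therefore has an open end.

Compound 2 (`CCCCNC(=O)NS(=O)(=O)c1ccc(OCC(CO[N+](=O)[O-])O[N+](=O)[O-])cc1`) gives 61000 nM. Within the data shown here, the one measured step is an at least 1.6-fold lower number from compound 1 to compound 2 (0.21 log units; that floor lies within the scatter). It adds a nitrooxy group in place of hydrogen on a saturated chain carbon bound to two saturated chain carbons, so it keeps the open chain and offers little guidance for a change of group type.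

Compound 4 (`CCCCNC(=O)NS(=O)(=O)c1ccc(OCc2no[n+]([O-])c2C(N)=O)cc1`) has not yet been measured. In it, the 2-(nitrooxy)ethyl on a saturated chain carbon bound to an oxygen on an aromatic ring is replaced: a group of 9 heavy atoms (3 carbon, 3 nitrogen, 3 oxygen; one five-membered aromatic ring with 3 hetero atoms) in place of a group of 6 heavy atoms (2 carbon, 1 nitrogen, 3 oxygen; no ring), on a saturated chain carbon bound to an oxygen on an aromatic ring.

The closer reference is compound 3 (`CCCCNC(=O)NS(=O)(=O)c1ccc(Oc2no[n+]([O-])c2S(=O)(=O)c2ccccc2)cc1`), which also carries a five-membered aromatic ring with 3 hetero atoms and gives 220 nM. Its ring is attached differently and bears a different group, so only part of that value should carry over to compound 4.

The expected change in this assay is a large move to a lower number, estimated as an at least 33-fold lower number from compound 1 to compound 4 (1.52 log units; beyond the scatter). For compound 4 the estimate is 3000 nM, with an expected range from 600 nM to 20000 nM.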

Compound 4, half-maximal effective concentration: 57000 nM
Compound 4: the middle estimate sits 19-fold (1.28 log units) below what was measured; the measured number lies above the stated range.
By their numbers in this assay, from the lowest: compound 3; then compounds 4 and 2 (each within the scatter of the next). At a limit, above all of these: compound 1.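

Notes on compound 4: in this assay, replacing the 2-(nitrooxy)ethyl with the group carrying a five-membered aromatic ring, on a saturated chain carbon bound to an oxygen on an aromatic ring, gives an at least 1.7-fold lower number from compound 1 to compound 4 (0.24 log units; that floor lies within the scatter). Compound 1 stands at a limit and not at a number, so this change can be read only as a floor: the limit of > 100000 nM in this assay, at which 1 of the 4 values shown sits. Compound 2 at 61000 nM and compound 4 at 57000 nM lie within the scatter of each other, so in this assay the ring-bearing group at this place cannot be told apart from the open chain with its two nitrooxy groups, and carrying this type of ring does not by itself bring a value in the range of compound 3 at 220 nM.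

Compound 3 and compound 4 differ in more than one place, in how the ring is attached and in the group it bears, so the shown compounds do not tell which of these matters. As far as these compounds go, a carboxylic acid or a nitrile in place of the amide group on the ring of compound 4, with the attachment kept, would be a single change at that site, and its effect remains open.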